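A Ketone Replaces an Alkyne on a Thioether Chain

This account rests on a few compounds, and the source may have more. Where it says the series, first, only, none or still open, it means among the compounds named here.

Compound 3 `C#CCSc1nnc(-c2cc(OC)c(OC)c(OC)c2)n1N1C(=O)c2ccccc2C1=O` carries a propargylsulfanyl group on the shared core. In a functional assay on HepG2 cells (Homo sapiens) for cytotoxicity, read by MTT assay, with a stated time of 48 h (on this read-out higher numbers stand for weaker inhibition and lower numbers for stronger inhibition), compound 3 gives > 200000 nM, which is a limit of the assay rather than a number. Two related compounds are also known. Compound 1 `CCCc1nnc(SCC(=O)c2ccc(C)cc2)n1N1C(=O)c2ccccc2C1=O` bears a (4-methylphenyl)carbonyl on a saturated chain carbon bound to a sulfur; in this assay compound 1 gives > 200000 nM, again a limit. Compound 2 `CCCc1nnc(SC)n1N1C(=O)c2ccccc2C1=O` has a methylsulfanyl group; in this assay compound 2 gives > 200000 nM, also a limit. Among the measured compounds shown here, the step that the two limits leave unreadable from compound 1 to compound 2 is therefore unreadable, and every value so far sits at the limit of > 200000 nM in this assay, at which 3 of the 3 values shown sit. Compound 4 `COc1ccc(C(=O)CSc2nnc(-c3cc(OC)c(OC)c(OC)c3)n2N2C(=O)c3ccccc3C2=O)cc1` differs from compound 3 by (4-methoxyphenyl)carbonyl in place of ethynyl on a saturated chain carbon bound to a sulfur. For the measured compounds named here, the only measured step at that place is the unreadable one, and compound 3 itself stands at a limit, so no size of step can be read from the data. Compound 4 is therefore expected to give about 200000 nM, between 80000 nM and 500000 nM, in this assay. The step of a number no higher from compound 3 to compound 4 (the limit leaves the size open) is expected to be none beyond the scatter.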

Compound 4, half-maximal inhibitory concentration: 28700 nM
For compound 4 the middle estimate is 7.0-fold (0.84 log units) above the measured one; measured number below the stated range.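

The chain carbon bound to a sulfur proves to be a place where a change can register: in this assay, (4-methoxyphenyl)carbonyl in place of ethynyl gives an at least 6.9-fold lower number from compound 3 to compound 4 (0.84 log units; beyond the scatter). The earlier pair could not show this, since the step between compound 1 and compound 2 cannot be read. Compound 4 thus gives the first value that is a number rather than a limit, and its step has only a lower bound, as the other compounds remain at that limit: the limit of > 200000 nM in this assay, at which 3 of the 4 values shown sit.

The compounds shown do not tell whether the carbonyl, the aromatic ring or the methoxy group accounts for the step. As far as these compounds go, how an amine, a carboxylic acid or a longer chain at this place would read in this assay also stays open.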